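The source may hold more compounds than are shown below. What is called first, only, known or untested is meant among the compounds shown, and "the series" means these compounds.

Of the compounds shown here, two built on a shared core have been measured in an assay on Sf9 cells for inhibition of mitogen-activated protein kinase kinase kinase 14 (Homo sapiens), read by ADP-Glo, with a stated time of 60 min; a higher number here means a weaker inhibitor, a lower number a stronger inhibitor. Compound 1 `CC(=O)n1nc(C)c(-c2ccc(Cl)c(Cl)c2)c1N` gives 8400 nM. Compound 2 `Cc1nn(C(=O)c2ccccc2)c(N)c1-c1ccc(Cl)c(Cl)c1`, which carries a phenyl rather than a methyl on the carbonyl carbon, gives 23000 nM. Going by the values given here, of these two numbers compound 2 stands highest, that is, it is the weaker inhibitor of the pair; its only neighbour is compound 1, and the step of a 2.7-fold higher number from compound 1 to compound 2 (0.44 log units; beyond the scatter) separates them.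

Compound 3 `Cc1nn(C(=O)c2cccnc2)c(N)c1-c1ccc(Cl)c(Cl)c1` differs from compound 2 in one place: pyridin-3-yl in place of phenyl on a carbonyl carbon. Among the compounds with values here, no measured step swaps a phenyl for a pyridin-3-yl, so nothing recorded speaks to this change directly. Within the data shown here, the one step that touches the same carbonyl carbon, a 2.7-fold higher number from compound 1 to compound 2 (0.44 log units; beyond the scatter), shows that exchanging the group there moved the number only modestly. For compound 3 a shift within or just beyond the scatter is therefore expected, with no direction clearly favoured, estimated as a 1.1-fold higher number from compound 2 to compound 3 (0.04 log units; within the scatter). The estimate for compound 3 in this assay is 25000 nM, with an expected range from 9000 nM to 60000 nM.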

Compound 3, half-maximal inhibitory concentration: > 100000 nM
Compound 3: no number, only a limit; the forecaster's own chance of this, stated with the estimate: 15%; middle value at least 4.0-fold (0.60 log units) away from the limit.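

In this assay compound 3 gives no exact number, only a limit of the assay: the limit of > 100000 nM in this assay, at which 1 of the 3 values shown sits. Even so, this result shows that the group on the carbonyl carbon matters more than the earlier pair could reveal: going from phenyl to pyridin-3-yl keeps the ring and the count of heavy atoms, exchanging one ring carbon for a nitrogen, yet it gives an at least 4.3-fold higher number from compound 2 to compound 3 (0.63 log units; beyond the scatter). Measured against the methyl group, the change gives an at least 11-fold higher number from compound 1 to compound 3 (1.07 log units; beyond the scatter), which, together with a 2.7-fold higher number from compound 1 to compound 2 (0.44 log units; beyond the scatter), leaves compound 1 as the strongest inhibitor of the three, and both aromatic rings on this carbon are poorer here than methyl.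

The compounds shown leave open how far past the limit compound 3 really lies, so the true size of both new steps remains unknown, and they do not say why the ring nitrogen has this effect. Also open, as far as these compounds go, is how the number would respond on this carbonyl carbon to pyridin-4-yl, an ethyl group or an amine such as dimethylamino.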